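Chain extension on the ring nitrogen of a tricyclic series

The source may report more compounds than this note shows. Statements on the series, on what has been measured and on what is new or still open speak of the compounds shown alone.

Measured so far:
Compound 1 `Cc1nn(C)c2c1C(c1ccccc1Cl)=NCCN2`: 2.5 mg/kg
Compound 2 `Cc1nn(C)c2c1C(c1ccccc1Cl)=NCCN2C`: 2.5 mg/kg

In a functional assay on the whole organism for positive allosteric modulation, with Rattus norvegicus as the target (on this read-out higher numbers stand for an effect only at larger amounts of compound and lower numbers for an effect already at smaller amounts), compound 1 gives 2.5 mg/kg and compound 2 gives 2.5 mg/kg. For the measured compounds named here, the only measured step, no change at the digits printed from compound 1 to compound 2 (within the scatter), lies within the scatter. Compound 3 `Cc1nn(C)c2c1C(c1ccccc1Cl)=NCCN2CCCN(C)C` carries the change (2-(dimethylamino)ethyl in place of hydrogen on a saturated chain carbon bound to a nitrogen on an aromatic ring in a ring). Going by the values given here, no measured step covers a chain of this length on that carbon, so the expectation for compound 3 rests on the flat step already seen. Compound 3 is therefore expected at 2.5 mg/kg in this assay, between 1 mg/kg and 6 mg/kg, with the estimated step of no change at the digits printed from compound 2 to compound 3 (within the scatter) not beyond the scatter.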

Compound 3, minimum effective dose: > 10 mg/kg
Compound 3: a limit, no number; the forecaster's own chance of this, stated with the estimate: 10%; middle value at least 4.0-fold (0.60 log units) away from the limit.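

The position on a nitrogen on an aromatic ring in a ring is not indifferent to substitution: the flat methyl step does not carry over to 3-(dimethylamino)propyl, which gives an at least 4.0-fold higher number from compound 1 to compound 3 (0.60 log units; beyond the scatter) in this assay. Extending the methyl with 2-(dimethylamino)ethyl likewise gives an at least 4.0-fold higher number from compound 2 to compound 3 (0.60 log units; beyond the scatter) in the same read-out. Compound 3 stands as a limit, not a number: the limit of > 10 mg/kg in this assay, at which 1 of the 3 values shown sits.

On these data alone, the size of the full loss stays open. So does whether a shorter chain such as ethyl, or a propyl chain ending in a hydroxyl group instead of the amine, stays level with compound 1 at 2.5 mg/kg in this assay.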